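The source may hold more compounds than are shown below. What is called first, only, known or untested is meant among the compounds shown, and "the series" means these compounds.

Two compounds of the series have numbers in a functional assay on L1210 cells (Mus musculus) for inhibition; on this read-out higher numbers stand for weaker inhibition and lower numbers for stronger inhibition. Compound 1 `OC[C@H]1OC(n2cnc3c(-c4ccco4)ncnc32)[C@H](O)[C@@H]1O` gives 2000 nM. For the measured compounds named here, compound 2 `OC[C@H]1OC(n2cnc3c(-c4cc[nH]c4)ncnc32)[C@H](O)[C@@H]1O` gives 17500 nM, the highest of the two numbers; its only neighbour is compound 1, separated by the step of an 8.8-fold higher number from compound 1 to compound 2 (0.94 log units; beyond the scatter). Compound 3 `OC[C@H]1OC(n2cnc3c(-c4ccccn4)ncnc32)[C@H](O)[C@@H]1O` has not been measured. The change is pyridin-2-yl in place of 1H-pyrrol-3-yl on an aromatic carbon: the five-membered ring with one hydrogen-bond donor leaves and a six-membered ring with one hydrogen-bond acceptor enters. Going by the values given here, the one measured step that bears on this is an 8.8-fold higher number from compound 1 to compound 2 (0.94 log units; beyond the scatter), where the ring with an acceptor was replaced by the ring with a donor. Going back to an acceptor-bearing ring is expected to lower the number for compound 3 by a 5.8-fold lower number from compound 2 to compound 3 (0.77 log units; beyond the scatter), with a wide spread because the six-membered ring has no counterpart among the measured pair. Compound 3 is estimated at 3000 nM, between 800 nM and 12000 nM.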

Compound 3, half-maximal inhibitory concentration: 4300 nM
Beside the measured number, compound 3's estimate is 1.4-fold (0.16 log units) below it, within the range that was stated.
By their numbers in this assay, from the lowest: compound 1; then compound 3; then compound 2.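

In this assay, a six-membered ring at this aromatic carbon falls within the range set by the two five-membered rings: pyridin-2-yl in place of 1H-pyrrol-3-yl gives a 4.1-fold lower number from compound 2 to compound 3 (0.61 log units; beyond the scatter), so ring size alone does not set the number here. Pyridin-2-yl in place of furan-2-yl gives a 2.2-fold higher number from compound 1 to compound 3 (0.33 log units; beyond the scatter), which leaves the furan-2-yl compound with the lowest number of the three. Nothing available explains this order among the three rings.

The compounds shown leave open whether an aromatic ring is needed at this carbon at all, a question that a dimethylamino group or a short alkyl chain would address. They also leave open how much the ring nitrogen of pyridin-2-yl counts, which a phenyl ring would test.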